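Swapping One Halogen Ring for Another on the Amide

This account rests on a few compounds, and the source may have more. Where it says the series, first, only, none or still open, it means among the compounds named here.

Three compounds share one core and differ only in the ring attached to an amide-type nitrogen. Compound 1 `CN(C)C(=O)c1cc2cnc(Nc3ccc(NC(=O)C4(C(=O)Nc5ccccc5F)CC4)cc3)nc2n1C1CCCC1` carries a 2-fluorophenyl there; compound 2 `CN(C)C(=O)c1cc2cnc(Nc3ccc(NC(=O)C4(C(=O)Nc5cccc(C(F)(F)F)c5)CC4)cc3)nc2n1C1CCCC1` a 3-(trifluoromethyl)phenyl; compound 3 `CN(C)C(=O)c1cc2cnc(Nc3ccc(NC(=O)C4(C(=O)Nc5cccc(Cl)c5)CC4)cc3)nc2n1C1CCCC1` a 3-chlorophenyl. In a functional assay on A549 cells (Homo sapiens) for inhibition, read by CCK-8 assay, with a stated time of 72 h, tested at 10 uM (on this read-out higher numbers stand for more inhibition of growth at the one concentration tested and lower numbers for less inhibition of growth), compound 1 gives 88.6%, compound 2 gives 89.2% and compound 3 gives 90.7%. The steps are a number 0.6 percentage points higher from compound 1 to compound 2 (within the scatter) and a number 2.1 percentage points higher from compound 1 to compound 3 (within the scatter), so the three numbers cannot be told apart, and the change of ring has so far left the read-out unmoved.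

Compound 4 `CN(C)C(=O)c1cc2cnc(Nc3ccc(NC(=O)C4(C(=O)Nc5cccc(Br)c5)CC4)cc3)nc2n1C1CCCC1` is not yet measured. It differs from compound 1 by 3-bromophenyl in place of 2-fluorophenyl on an amide-type nitrogen. The step from compound 1 to compound 3, a number 2.1 percentage points higher from compound 1 to compound 3 (within the scatter), and the step from compound 2 to compound 3, a number 1.5 percentage points higher from compound 2 to compound 3 (within the scatter), are the closest guides, as each puts a different halogen on the same part of the ring, and both stayed within the scatter. No change beyond the scatter is therefore expected in this assay. For compound 4 the estimate is 90%, between 84% and 95%, meaning an expected step of a number 1.4 percentage points higher from compound 1 to compound 4 (within the scatter).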

Compound 4, percent growth inhibition at one concentration: 92.2%
Estimate against measurement, compound 4: 2.2 percentage points below, and the stated range covers the measured number.
By their numbers in this assay, from the lowest: compounds 1, 2, 3 and 4 (each within the scatter of the next).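

With bromo as a further group on the ring, the amide-type nitrogen still shows no measurable response to the change: in this assay, 3-bromophenyl in place of 2-fluorophenyl gives a number 3.6 percentage points higher from compound 1 to compound 4 (within the scatter). The two swaps made directly on the aromatic carbon read the same way, with bromo in place of chloro giving a number 1.5 percentage points higher from compound 3 to compound 4 (within the scatter) and bromo in place of trifluoromethyl giving a number 3 percentage points higher from compound 2 to compound 4 (within the scatter), so all four rings remain indistinguishable in this read-out. Nothing measured here offers an explanation for how closely these numbers agree.

Still open, going by these compounds, is whether a carboxylic acid or an amine on this ring, or a longer alkyl chain in place of the ring, would move the number beyond the scatter. With only one tested concentration, it is also unknown whether these four compounds would separate at lower concentrations.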